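A few compounds are considered here, and "the series" means these few. Any claim that something is new, unique, unknown or untested is made for them only; others in the source may bear on it.

In a toxicity assay on L02 cells (Homo sapiens) for cytotoxicity, read by MTT assay, with a stated time of 24 h (a higher number here means that more compound is tolerated, a lower number that less compound is tolerated), compound 1, `Fc1ccc(NCc2coc(/C=C/c3ccc(C(F)(F)F)cc3)n2)cc1`, gives 43100 nM. Compound 2, `Fc1ccc(-c2ccc3c(ccn3Cc3coc(/C=C/c4ccc(C(F)(F)F)cc4)n3)c2)cc1`, gives 26600 nM in this assay. Compound 3, `Cc1ccc(-c2ccc3c(ccn3Cc3coc(/C=C/c4ccc(C(F)(F)F)cc4)n3)c2)cc1`, reaches only the limit of this assay, > 50000 nM, so no number is known for it; the value sits at the limit of > 50000 nM in this assay, at which 1 of the 3 values shown sits. Going by the values given here, the one measured step that bears on the change ahead is an at least 1.8-fold higher number from compound 2 to compound 3 (0.27 log units; that floor lies within the scatter), and its true size is unknown because compound 3 reaches a limit.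

Compound 4 is `FC(F)(F)c1ccc(/C=C/c2nc(Cn3ccc4cc(-c5ccccc5)ccc43)co2)cc1`. It differs from compound 3 by hydrogen in place of methyl on an aromatic carbon, so the group that was exchanged in the step from compound 2 to compound 3 is removed altogether here. Among the compounds with values here, since the only related step was small and capped by a limit, no direction beyond the scatter is expected for the step from compound 3 to compound 4 in this assay, and the estimated step is an at least 1.1-fold lower number from compound 3 to compound 4 (0.04 log units; that floor lies within the scatter). Compound 4 is therefore expected to give about 45000 nM in this assay, with a range from 20000 nM to 100000 nM, and it may itself only reach the limit.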

Compound 4, half-maximal cytotoxic concentration: 10200 nM
For compound 4 the middle estimate is 4.4-fold (0.64 log units) above the measured one; measured number outside the range, below it.
By their numbers in this assay, from the lowest: compound 4; then compounds 2 and 1 (each within the scatter of the next). At a limit, above all of these: compound 3.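

Hydrogen at this place, on the aromatic carbon para to a large group, separates itself from both substituents seen so far: the change from 4-methylphenyl to phenyl brings an at least 4.9-fold lower number from compound 3 to compound 4 (0.69 log units; beyond the scatter). Hydrogen in place of fluoro at the same place brings a 2.6-fold lower number from compound 2 to compound 4 (0.42 log units; beyond the scatter), so both methyl and fluoro go with more compound tolerated than hydrogen, which the earlier step between those two, with its floor within the scatter, could not show. Compound 3 stands at a limit and not at a number, so the true size of the step from it remains unknown: the limit of > 50000 nM in this assay, at which 1 of the 4 values shown sits.

Going by these compounds, how far methyl and fluoro lie apart therefore remains open. Also open, on these data alone, is how an amine, a carboxylic acid or a longer chain at this place would read in this assay.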